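Cytotoxicity notes on a biaryl sulfonamide series

This account rests on a few compounds, and the source may have more. Where it says the series, first, only, none or still open, it means among the compounds named here.

Compound 1 `CN1CCN(S(=O)(=O)c2ccc(-c3ccc4c(Nc5ccc(OCc6cccc(F)c6)c(Cl)c5)cnnc4c3)cc2)CC1` carries a 4-methylpiperazin-1-yl group on the sulfonyl sulfur. In a toxicity assay on HepG2 cells (Homo sapiens) for cytotoxicity, read by MTT assay, with a stated time of 48 h (on this read-out higher numbers stand for lower toxicity in this test and lower numbers for higher toxicity in this test), compound 1 reaches only a limit, > 15 uM. Compound 2 `CN1CCCN(S(=O)(=O)c2ccc(-c3ccc4c(Nc5ccc(OCc6cccc(F)c6)c(Cl)c5)cnnc4c3)cc2)CC1` in this assay gives 15 uM. The step of a number no higher from compound 1 to compound 2 (the limit leaves the size open) comes from the change (4-methyl-1,4-diazepan-1-yl in place of 4-methylpiperazin-1-yl on a sulfonyl sulfur). Its size cannot be read, since the value of compound 1 sits at the limit described by the limit of > 15 uM in this assay, at which 1 of the 3 values shown sits.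

Compound 3 `CN1CCN(S(=O)(=O)c2ccc(-c3ccc4cnnc(Nc5ccc(OCc6cccc(F)c6)c(Cl)c5)c4c3)cc2)CC1` has the same atoms as compound 1 joined differently; the difference between the two cores is not broken down here. In this assay compound 3 also gives only a limit, > 5 uM, the limit described by the limit of > 5 uM in this assay, at which 1 of the 3 values shown sits.

Compound 4 `CN1CCCN(S(=O)(=O)c2ccc(-c3ccc4cnnc(Nc5ccc(OCc6cccc(F)c6)c(Cl)c5)c4c3)cc2)CC1` is not yet measured. It differs from compound 3 by 4-methyl-1,4-diazepan-1-yl in place of 4-methylpiperazin-1-yl on a sulfonyl sulfur, the same change as from compound 1 to compound 2, at the same place. The expected step that the limit leaves unreadable from compound 3 to compound 4 rests on the unreadable step a number no higher from compound 1 to compound 2 (the limit leaves the size open) and on the limit of compound 3. Compound 4 is expected near 12 uM, between 5 uM and 30 uM.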

Compound 4, half-maximal toxic concentration: 14 uM
Compound 4: the middle estimate sits 1.2-fold (0.07 log units) below what was measured; the range from low to high includes it.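

No size can be read for the step between compound 3 and compound 4, since compound 3 gives only a limit: the limit of > 5 uM in this assay, at which 1 of the 4 values shown sits.

The compounds shown leave open how large the change from 4-methylpiperazin-1-yl to 4-methyl-1,4-diazepan-1-yl on a sulfonyl sulfur is on either core, as compound 1 and compound 3 both stand at limits.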